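From Methoxy to (Dimethylamino)methyl on the Shared Core

This account rests on a few compounds, and the source may have more. Where it says the series, first, only, none or still open, it means among the compounds named here.

Measured so far in an ADME assay on HEK293 cells (Homo sapiens) for cytotoxicity, with a stated time of 6 h (a higher number here means that more compound is tolerated, a lower number that less compound is tolerated), each value being a limit:
Compound 1 `CCCNc1nc(N)nc2ccccc12`: > 25000 nM
Compound 2 `CC(C)CCNc1nc(N)nc2ccccc12`: > 25000 nM
Compound 3 `CCCCNc1nc(N)nc2cc(OC)ccc12`: > 18000 nM

Compound 3 has no numerical value, only a limit of > 18000 nM. Compound 4 `CCCCNc1nc(N)nc2cc(CN(C)C)ccc12` is still to be measured. It differs from compound 3 by a single change, with (dimethylamino)methyl in place of methoxy on an aromatic carbon. Within the data shown here, the only measured step is a step that the two limits leave unreadable from compound 1 to compound 2. That step lies on the saturated chain rather than on an aromatic carbon, and it offers no size to carry over. Among the measured compounds shown here, no measured step covers the present change, so the expectation rests on the limit of compound 3, > 18000 nM. On that basis, no step beyond the usual scatter is expected in this assay, and a limit is again the likeliest result. The estimated outcome is a step that the limit leaves unreadable from compound 3 to compound 4. For compound 4 the expected value is 20000 nM. The estimated range for compound 4 runs from 8000 nM to 45000 nM.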

Compound 4, half-maximal cytotoxic concentration: > 18000 nM
Compound 4 ended at the assay's limit; the forecaster's own chance of this, stated with the estimate: 60%; the middle value does not contradict the limit.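

Among these compounds, compound 3 and compound 4 both stand only as limits in this assay, so no step between them can be read. The compounds shown leave open where the half-maximal cytotoxic concentration of any of them lies, and whether (dimethylamino)methyl in place of methoxy changes it at all.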